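Benzofuran for furan on two related nucleoside cores

The source may hold more compounds than are shown below. What is called first, only, known or untested is meant among the compounds shown, and "the series" means these compounds.

Four nucleoside-like compounds are compared in an ADME assay on BJ cells (Homo sapiens), read by MTT assay, with a stated time of 72 h; a lower number here means a stronger inhibitor, a higher number a weaker inhibitor. Compound 1 `O=c1[nH]cnc2c1c(-c1ccoc1)cn2[C@@H]1O[C@H](CO)[C@@H](O)[C@H]1O` gives only a limit of the assay in this assay, > 100000 nM. Compound 2 `O=c1[nH]cnc2c1c(-c1cc3ccccc3o1)cn2[C@@H]1O[C@H](CO)[C@@H](O)[C@H]1O` gives 62700 nM in this assay. The change between them is 1-benzofuran-2-yl in place of furan-3-yl on an aromatic carbon, and it made an at least 1.5-fold lower number from compound 1 to compound 2 (0.20 log units; that floor lies within the scatter), which rests on (the limit of > 100000 nM in this assay, at which 2 of the 3 values shown sit).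

Compound 3 `Nc1nc(N)c2c(-c3ccoc3)cn([C@@H]3O[C@H](CO)[C@@H](O)[C@H]3O)c2n1` has a different core; the difference between the two cores is not broken down here. In this assay compound 3 gives only a limit of the assay, > 100000 nM. Compound 4 `Nc1nc(N)c2c(-c3cc4ccccc4o3)cn([C@@H]3O[C@H](CO)[C@@H](O)[C@H]3O)c2n1`, not yet measured, carries the same change on the core of compound 3: 1-benzofuran-2-yl in place of furan-3-yl on an aromatic carbon.

Because compound 3 sits at the limit and the earlier change gave only an at least 1.5-fold lower number from compound 1 to compound 2 (0.20 log units; that floor lies within the scatter), the step from compound 3 to compound 4 is expected to be small, estimated as an at least 1.2-fold lower number from compound 3 to compound 4 (0.09 log units; that floor lies within the scatter). Compound 4 is therefore estimated at 80000 nM in this assay, most likely between 35000 nM and 200000 nM, with a real chance that only a limit is reported again.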

Compound 4, half-maximal inhibitory concentration: > 100000 nM
Compound 4: a limit, no number; the forecaster's own chance of this, stated with the estimate: 50%; middle value at least 1.2-fold (0.09 log units) away from the limit.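

Compound 3 and compound 4 both give only a limit of the assay in this assay, so the size of the step between them cannot be read: the limit of > 100000 nM in this assay, at which 3 of the 4 values shown sit.

The compounds shown leave open whether 1-benzofuran-2-yl in place of furan-3-yl changes the number at all on the core of compound 3, and so whether the change behaves alike on the two cores.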